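This account rests on a few compounds, and the source may have more. Where it says the series, first, only, none or still open, it means among the compounds named here.

Of the compounds shown here, three built on one shared core have so far been tested in a functional assay on HT29-AK cells (Homo sapiens) for cytotoxicity, read by MTT assay, with a stated time of 48 h; a higher number here means a weaker inhibitor, a lower number a stronger inhibitor. Compound 1 `COc1ccccc1Nc1nc(-c2cccc(F)c2)nc2ccc(F)cc12` gives only a limit of the assay there, > 50000 nM. Compound 2 `Fc1cccc(-c2nc(Nc3ccccc3F)c3cc(F)ccc3n2)c1` likewise gives only a limit in this assay, > 50000 nM. Compound 3 `Nc1cccc(Nc2nc(-c3cccc(F)c3)nc3ccc(F)cc23)c1` also reaches only a limit in this assay, > 50000 nM. Because (the limit of > 50000 nM in this assay, at which 3 of the 3 values shown sit), none of the changes among these three can be sized: the step that the two limits leave unreadable from compound 1 to compound 2, the step that the two limits leave unreadable from compound 1 to compound 3 and the step that the two limits leave unreadable from compound 2 to compound 3 all stay unreadable. On the numbers shown, compound 2 therefore stands at the limit of the assay, with no place within it that can be told apart from the other two.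

Compound 4 `Nc1ccccc1Nc1nc(-c2cccc(F)c2)nc2ccc(F)cc12` has not yet been measured in this assay. It differs from compound 2 in one place: amino in place of fluoro on an aromatic carbon. The three measured steps bear on this only loosely, since each swaps one group on the same kind of ring, and none of them yields a readable size. Among the measured compounds shown here, there is thus no measured step to expect a change in this assay beyond the scatter, in either direction. Compound 4 is expected to give about 70000 nM in this assay, most likely again as a limit, within a range from 20000 nM to 250000 nM. The step that the limit leaves unreadable from compound 2 to compound 4 is accordingly estimated to be small, if readable at all.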

Compound 4, half-maximal inhibitory concentration: > 50000 nM
Compound 4 ended at the assay's limit; the forecaster's own chance of this, stated with the estimate: 80%; the middle value lies beyond the limit too.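

Compound 4 joins compound 1, compound 2 and compound 3 at the limit of the assay, and no step among these four compounds can be read, because all of them share that one limit: (the limit of > 50000 nM in this assay, at which 4 of the 4 values shown sit).

Still open, as far as these compounds go, is whether any other group on the shared core would give a readable value in this assay and how far these four compounds truly differ.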